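Working notes: from compound 3 to compound 4

A few compounds are considered here, and "the series" means these few. Any claim that something is new, unique, unknown or untested is made for them only; others in the source may bear on it.

- compound 1 `O=C1Nc2ccc(F)cc2/C1=C\C(=O)c1ccc[nH]1`: 6420 nM
- compound 2 `O=C1Nc2ccc(F)cc2/C1=C\C(=O)c1cnc2ccc(Cl)nn12`: 8020 nM
- compound 3 `COc1ccc(C(=O)Nc2ccc3c(c2)/C(=C/Nc2cccc(N4CCN(C)CC4)c2)C(=O)N3)cc1`: 3170 nM

All three numbers come from a functional assay on BGC-823 cells (Homo sapiens) for inhibition, read by sulforhodamine B assay, with a stated time of 3 days; on this read-out lower numbers stand for stronger inhibition and higher numbers for weaker inhibition. Compound 3 has the lowest of the three numbers, and its distance to each of the other two lies beyond the scatter.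

Compound 4 `CC(C)CC(=O)Nc1ccc2c(c1)/C(=C/Nc1cccc(N3CCN(C)CC3)c1)C(=O)N2` has not yet been measured. It differs from compound 3 by isobutyl in place of 4-methoxyphenyl on a carbonyl carbon. Going by the values given here, no measured pair in this small set shows a change of this kind, so the size of the step cannot be read from the data. The expectation rests on compound 3 at 3170 nM alone, and the range is kept wide.

In this assay, no step beyond the scatter is expected, and the estimated 1.3-fold higher number from compound 3 to compound 4 (0.10 log units; within the scatter) leans slightly towards a higher number. For compound 4 the expected value is 4000 nM, with an estimated range of 1400 nM to 11000 nM.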

Compound 4, half-maximal inhibitory concentration: 6080 nM
The estimate for compound 4 lay 1.5-fold (0.18 log units) below the measured number; the range from low to high includes it.
By their numbers in this assay, from the lowest: compounds 3, 4, 1 and 2 (each within the scatter of the next, the first and the last beyond it).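

Going by these compounds alone, this is the first pair that differs in one place, and in this assay isobutyl in place of 4-methoxyphenyl on this carbonyl carbon gives a 1.9-fold higher number from compound 3 to compound 4 (0.28 log units; within the scatter) in a single step. At this position, the six-membered aromatic ring and its hydrogen-bond acceptor can therefore leave, with the smaller ring-free isobutyl entering, without a step beyond the scatter. Nothing measured bears on why the step has this size.

The compounds shown leave open whether an amine, a carboxylic acid or a longer chain on this carbonyl carbon would give a step beyond the scatter. They also leave open whether plain phenyl would read differently from 4-methoxyphenyl, which would separate the contribution of the ring from that of its methoxy group.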